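Swapping a Methylsulfonyl Pyrazole for a Pyridine

The compounds below may be only part of what the source reports. "The series", "measured", "known", "first", "only" and "open" are said of these compounds alone.

Measured compounds:
compound 1 `CNC(=O)N1CCCc2ccc(NC(=O)c3cccc(-c4ccccc4)c3)cc21` — 2.83%
compound 2 `CNC(=O)N1CCCc2ccc(NC(=O)c3ccc(-c4cnn(S(C)(=O)=O)c4)cc3)cc21` — 4.5%

In a functional assay on MV4-11 cells (Homo sapiens) for antiproliferative activity, with a stated time of 6 days, tested at 1.56 uM (a lower number here means a weaker effect, a higher number a stronger effect of the compound at the concentration tested), compound 2 gives 4.5%, the higher of the two numbers. Its nearest neighbour, compound 1, gives 2.83%, and the two values lie within the scatter of each other, so neither can be called the stronger. Both numbers are small: at this concentration, hardly any of the cell growth is held back by either compound.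

Compound 3 `CNC(=O)N1CCCc2ccc(NC(=O)c3ccc(-c4ccccn4)cc3)cc21` has not yet been tested. It differs from compound 2 in one place: pyridin-2-yl in place of 1-(methylsulfonyl)-1H-pyrazol-4-yl on an aromatic carbon. Among the compounds with values here, no step between two measured compounds shows what such a change does here, and compound 2 itself sits close to the floor of the read-out. With nothing pointing either way, the step from compound 2 to compound 3 is expected to be small, no larger than the usual scatter: a number 0.5 percentage points lower from compound 2 to compound 3 (within the scatter). For compound 3, a value of 4% is estimated, most likely between 0% and 12%.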

Compound 3, a percentage reported as inhibition, at one concentration (the size of the read-out at that concentration, not a potency): 32%
For compound 3 the middle estimate is 28 percentage points below the measured one; the measured number lies above the stated range.
By their numbers in this assay, from the lowest: compounds 1 and 2 (each within the scatter of the next); then compound 3.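

In this assay putting pyridin-2-yl in place of 1-(methylsulfonyl)-1H-pyrazol-4-yl gives a number 27.5 percentage points higher from compound 2 to compound 3 (beyond the scatter) and shows that this place, para to a large group, can lift the read-out clear of the low level seen so far. The change swaps a five-membered aromatic ring of 9 heavy atoms with its methylsulfonyl group for a six-membered aromatic ring of 6 heavy atoms, so several features differ at once. No measurement at hand explains the step.

This single step leaves open which of those differences matters: the ring size, the loss of the methylsulfonyl group, or the pyridine nitrogen. Going by these compounds, it also remains open whether pyridin-4-yl, or a ring carrying an amine, would raise or lower the read-out at this place.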